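The source may report more compounds than this note shows. Statements on the series, on what has been measured and on what is new or still open speak of the compounds shown alone.

Within the data shown here, compound 2, with structure `Nc1scc(CN2CCN(c3ccc([N+](=O)[O-])cc3)CC2)c1C(=O)c1ccc(Cl)cc1`, stands at the top of the two numbers measured so far: in a functional assay on CHO cells with adenosine receptor A1 (Homo sapiens) as the target, read by cAMP accumulation and immunoassay, with a stated time of 6 min, tested at 10 uM (on this read-out higher numbers stand for a weaker effect at the one concentration tested and lower numbers for a stronger effect), compound 2 gives -17%. Among the measured compounds shown here, its one neighbour is compound 1, structure `Nc1scc(CN2CCN(c3ccc(F)cc3Cl)CC2)c1C(=O)c1ccc(Cl)cc1`, which in this assay gives -70%. For the measured compounds named here, the only measured step, a number 53 percentage points higher from compound 1 to compound 2 (beyond the scatter), shows that exchanging the aryl group on the amine nitrogen in the ring moves the read-out by a large amount.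

Compound 3, structure `Nc1scc(CN2CCN(c3ccc(OC(F)(F)F)cc3)CC2)c1C(=O)c1ccc(Cl)cc1`, differs from compound 2 by trifluoromethoxy in place of nitro on an aromatic carbon. Going by the values given here, no measured pair carries the trifluoromethoxy group, so the step from compound 1 to compound 2 bears on it only by showing how sensitive this read-out is to the group on that aryl ring. Given that sensitivity, the author expects compound 3 to land between the two measured values rather than beyond them, and estimates for compound 3 a value of -40% in this assay, with a range from -75% to 0%; this means an expected step of a number 23 percentage points lower from compound 2 to compound 3 (beyond the scatter).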

Compound 3, a percentage reported as activity, at one concentration (the size of the read-out at that concentration, not a potency): -74%
For compound 3 the middle estimate is 34 percentage points above the measured one, and the stated range covers the measured number.
By their numbers in this assay, from the lowest: compounds 3 and 1 (each within the scatter of the next); then compound 2.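

Trifluoromethoxy in place of nitro on an aromatic carbon, para to a large group, gives a number 57 percentage points lower from compound 2 to compound 3 (beyond the scatter) in this assay and so shows that exchanging this one group, with no second substituent on that aryl ring, is enough for a large move in the read-out. Among these compounds, the other new step, a number 4 percentage points lower from compound 1 to compound 3 (within the scatter) shows that two different aryl groups, 4-(trifluoromethoxy)phenyl and 2-chloro-4-fluorophenyl, give numbers that cannot be told apart in this read-out, which leaves the 4-nitrophenyl of compound 2 as the one aryl group of the three that stands apart. Nothing given here accounts for why the nitro group stands apart from the other two aryl groups.

On these data alone, it remains open where other groups on that aromatic carbon, such as an amine, a methoxy group or a carboxylic acid, would fall relative to nitro and trifluoromethoxy. As far as these compounds go, all three compounds also share the rest of the core, so it is equally open whether the large step from nitro to trifluoromethoxy would persist with a methyl or a methoxy group in place of the chloro group on the other aromatic ring.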